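The source may report more compounds than this note shows. Statements on the series, on what has been measured and on what is new or still open speak of the compounds shown alone.

Compound 1 `CN1CCN(c2ccc(Nc3ncc4c(n3)N(C3CCCC3)CC(=O)N4)cc2)CC1` is examined in an ADME assay on HEK293 cells (Homo sapiens) for inhibition, read by MTT assay, with a stated time of 48 h; a lower number here means a stronger inhibitor, a higher number a weaker inhibitor. In this assay compound 1 gives > 30000 nM, which is a limit of the assay rather than a number. Compound 1 sits at the limit of > 30000 nM in this assay, at which 1 of the 2 values shown sits. Compound 2 `O=C1CN(C2CCCC2)c2nc(Nc3ccc(N4CCCCC4)cc3)ncc2N1` gives 25100 nM in this assay. The step of an at least 1.1-fold lower number from compound 1 to compound 2 (0.07 log units; that floor lies within the scatter) changes a group on the aromatic ring, a different place from the one altered here. Compound 3 `CCN1C(=O)CN(C2CCCC2)c2nc(Nc3ccc(N4CCN(C)CC4)cc3)ncc21` differs from compound 1 by ethyl in place of hydrogen on an amide-type nitrogen in a ring. Within the data shown here, no measured step alters that ring nitrogen, so for compound 3 no shift beyond the scatter is expected, a number no higher from compound 1 to compound 3 (the limit leaves the size open). Compound 3 is estimated at 30000 nM, between 12000 nM and 75000 nM.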

Compound 3, half-maximal inhibitory concentration: > 30000 nM
Compound 3 ended at the assay's limit; the forecaster's own chance of this, stated with the estimate: 60%; the middle value lies on the limit itself.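

Among these compounds, compound 1 and compound 3 both sit at a limit of the assay rather than at a number, so no step between them can be read: the limit of > 30000 nM in this assay, at which 2 of the 3 values shown sit. On these data alone, whether ethyl in place of hydrogen on that ring nitrogen shifts the number in this assay at all stays open.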